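Saturating the Acid Side Chain on a Shared Core

The source may hold more compounds than are shown below. What is called first, only, known or untested is meant among the compounds shown, and "the series" means these compounds.

Three compounds on one core were measured in a functional assay on HL-60 cells (Homo sapiens) for antiproliferative activity, read by trypan blue exclusion; a higher number here means a weaker inhibitor of growth, a lower number a stronger inhibitor of growth:

Compound 1 `C=C1CC[C@@H]2[C@](C)(CO)[C@H](O)CC[C@@]2(C)[C@@H]1CCC1=CCOC1=O`: 25500 nM
Compound 2 `C=C1CC[C@@H]2[C@](C)(CO)[C@H](O)CC[C@@]2(C)[C@@H]1CC/C(=C/CO)C(=O)O`: 22400 nM
Compound 3 `C=C1CC[C@@H]2[C@](C)(CO)[C@H](O)CC[C@@]2(C)[C@@H]1/C=C/C(=O)O`: 28800 nM

Compound 3 gives the highest of the three numbers, yet its neighbours sit close: compound 1 differs by a 1.1-fold higher number from compound 1 to compound 3 (0.05 log units; within the scatter), and the gap to compound 2 is likewise within the scatter. Compound 4 `C=C1CC[C@@H]2[C@](C)(CO)[C@H](O)CC[C@@]2(C)[C@@H]1CCC(=O)O` differs from compound 3 only in the side chain: 2-carboxyethyl in place of 2-carboxyethenyl on a saturated ring carbon.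

Two measured steps speak to changes of this side chain. Going from compound 1 to compound 2 the chain was opened, with a 1.1-fold lower number from compound 1 to compound 2 (0.06 log units; within the scatter); going from compound 1 to compound 3 it was cut down to the 2-carboxyethenyl group, with a 1.1-fold higher number from compound 1 to compound 3 (0.05 log units; within the scatter). Neither reshaping of the chain moved the number beyond the scatter. The step to compound 4 is smaller still, a loss of one double bond outside aromatic rings while the rest of the chain stays. Compound 4 is therefore expected to stay close to compound 3 in this assay, with a step of a 1.1-fold lower number from compound 3 to compound 4 (0.03 log units; within the scatter), no larger than the scatter. The estimate for compound 4 is 27000 nM, with a range from 13000 nM to 55000 nM.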

Compound 4, concentration for 50% growth inhibition: 25000 nM
Estimate against measurement, compound 4: 1.1-fold (0.03 log units) above; the measured number falls inside the stated range.
By their numbers in this assay, from the lowest: compounds 2, 4, 1 and 3 (each within the scatter of the next).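

Saturating the 2-carboxyethenyl group to the 2-carboxyethyl group on this saturated ring carbon, with a 1.2-fold lower number from compound 3 to compound 4 (0.06 log units; within the scatter) in this assay, shows that the double bond in this chain can go without the number leaving the scatter. The shorter acid chain of compound 4 also stays within the scatter of both larger side chains, with a 1.1-fold higher number from compound 2 to compound 4 (0.05 log units; within the scatter) and with a 1.0-fold lower number from compound 1 to compound 4 (0.01 log units; within the scatter), so the unsaturated acid, the saturated acid, the opened chain and the five-membered ring of compound 1 all read alike at this position. No measurement of any other kind bears on this result, so the flatness of these numbers stands without an explanation.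

The compounds shown leave open whether any change of this side chain can move the number beyond the scatter, since every chain here still carries a carbonyl group; a primary amine or a primary amide in place of the carboxylic acid would test this. They also leave open whether the same flat picture would hold for a methyl ester of compound 4 or for a longer chain ending in the carboxylic acid.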